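The source may hold more compounds than are shown below. What is called first, only, known or untested is meant among the compounds shown, and "the series" means these compounds.

Measured so far:
- compound 1, `CN1CCC(C(=O)N2Cc3c(NC(=O)c4ccc5ccccc5c4)n[nH]c3C2(C)C)CC1`, giving 219000 nM in a physicochemical assay for solubility, at pH 7; on this read-out lower numbers stand for lower solubility and higher numbers for higher solubility
- compound 2, `CN(C)CC(=O)Nc1n[nH]c2c1CN(C(=O)C(C)(C)C)C2(C)C`, for which this assay reports only a limit, > 225000 nM, not a number

Compound 1 holds the only number shown in this assay; the one further entry is a limit. Within the set the value of compound 1 sits close to the top of what this assay can report, as the limit of > 225000 nM in this assay, at which 1 of the 2 values shown sits, shows.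

Compound 3 is `CN1CCC(C(=O)N2Cc3c(NC(=O)c4ccncc4)n[nH]c3C2(C)C)CC1`, not yet measured in this assay. It differs from compound 1 in one place: pyridin-4-yl in place of naphthalen-2-yl on a carbonyl carbon. Among the compounds with values here, no step between measured compounds is available to calibrate this change, so no size is assigned from the data themselves. Given (the limit of > 225000 nM in this assay, at which 1 of the 2 values shown sits), the room for an upward step in this assay is small, and an outcome at the limit is the most likely expectation.

Compound 3 is therefore estimated at 225000 nM in this assay, with a range of 150000 nM to 225000 nM. This corresponds to an expected step of a 1.0-fold higher number from compound 1 to compound 3 (0.01 log units; within the scatter), not beyond the scatter.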

Compound 3, solubility: > 225000 nM
Compound 3 was reported as a limit (the forecaster's own chance of this, stated with the estimate: 75%); the middle value sits exactly at the limit.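

In this assay, the place on the carbonyl carbon now has its first step: pyridin-4-yl in place of naphthalen-2-yl gives an at least 1.0-fold higher number from compound 1 to compound 3 (0.01 log units; that floor lies within the scatter). Compound 3 gives > 225000 nM, which is a limit and not a number. The step is therefore only a floor, and its true size cannot be read, since the values shown crowd the top of what the read-out can report: the limit of > 225000 nM in this assay, at which 2 of the 3 values shown sit.

Open, from the compounds shown here alone, is whether a phenyl ring, or a short chain ending in a carboxylic acid, on the same carbonyl carbon would give a number rather than a limit in this assay. Such values would begin to show whether the ring nitrogen of pyridin-4-yl matters at this place, which this single pair cannot tell.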